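Carboxy in Place of Hydroxy: What to Expect of Compound 4

This account rests on a few compounds, and the source may have more. Where it says the series, first, only, none or still open, it means among the compounds named here.

Measured compounds:
Compound 1 `CCc1ccc2nc(C(=O)Nc3c(F)cc(-c4cccc(F)c4)cc3F)c(C)c(O)c2c1`: in a functional assay on Hep 3B2 cells (Homo sapiens) for antiproliferative activity, read by MTT assay, with a stated time of 24 h, tested at 1.23 ug/mL (a lower number here means a weaker effect, a higher number a stronger effect of the compound at the concentration tested), compound 1 gives 23.5%.
Compound 2 `COc1ccc2nc(C(=O)Nc3ccc(-c4ccccc4)cc3)c(C)c(O)c2c1`: in this assay compound 2 gives 14.2%.
Compound 3 `CCc1ccc2nc(C(=O)Nc3c(F)cc(-c4cccc(F)c4)cc3F)c(C)c(C(=O)O)c2c1`: in this assay compound 3 gives 4.52%.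

Compound 4 `COc1ccc2nc(C(=O)Nc3ccc(-c4ccccc4)cc3)c(C)c(C(=O)O)c2c1` has not yet been measured in this assay. It is related to compound 2 in the same way that compound 3 is related to compound 1; how the cores of compound 1 and compound 2 differ is not broken down here. The change from compound 1 to compound 3 is carboxy in place of hydroxy on an aromatic carbon and it made the step of a number 19 percentage points lower from compound 1 to compound 3 (beyond the scatter). The change from compound 2 to compound 4 is carboxy in place of hydroxy on an aromatic carbon, the same change at the same place, occurring twice among these compounds.

Compound 2 starts from a lower number than compound 1, so the read-out cannot fall by the whole earlier amount without reaching the bottom of the scale. The expected step is a number 11.2 percentage points lower from compound 2 to compound 4 (beyond the scatter), which rests on the step of a number 19 percentage points lower from compound 1 to compound 3 (beyond the scatter) and on compound 2 giving 14.2%. Compound 4 is therefore expected to give about 3%, with the estimate lying between -5% and 12%. This rests on a single earlier pair, so the confidence is limited.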

Compound 4, a percentage reported as inhibition, at one concentration (the size of the read-out at that concentration, not a potency): 11.3%
Compound 4: middle estimate off by 8.3 percentage points, on the low side; low and high end bracket the measured number.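

In this assay, among these compounds, placing carboxy instead of hydroxy on the aromatic carbon opposite the ring nitrogen gave a number 2.9 percentage points lower from compound 2 to compound 4 (within the scatter), so on this core the change left no step that can be told from scatter. Read beside the earlier pair, the change did not carry over at the same size from one core to the other: the same change on two cores in this assay, a number 19 percentage points lower (beyond the scatter) from compound 1 to compound 3 and a number 2.9 percentage points lower (within the scatter) from compound 2 to compound 4, 16.1 percentage points apart, beyond the scatter of two such steps

This shows that the size of the step seen on the core of compound 1 cannot simply be transferred to other cores in this series, but it does not show which of the several differences between the two cores goes with the gap, and two pairs of compounds support no general rule about this change.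

The compounds shown leave open how an amine or a methyl ester at this place would compare with hydroxy and carboxy on either core. They also leave open how the step would run on a core that differs from the core of compound 1 or the core of compound 2 in one place only, which would begin to separate the differences that the two pairs leave bundled together.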